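The source may report more compounds than this note shows. Statements on the series, on what has been measured and on what is new or still open speak of the compounds shown alone.

Compound 1 `CC(C)(C)N1CCC(c2cc(-c3ccc(F)cc3F)c3ccc(=O)n(-c4c(Cl)cccc4Cl)c3c2)CC1` and compound 2 `CC(C)(C)N1CCC(c2cc3c(ccc(=O)n3-c3c(Cl)cccc3Cl)c(-c3ccc(F)cc3F)n2)CC1` have both been measured in an in vivo ADME assay on the whole organism (plasma) for pharmacokinetics, with Rattus norvegicus as the target; on this read-out higher numbers stand for fast clearance and lower numbers for slow clearance. In this test compound 1 gives 11.9 mL/min/kg and compound 2 gives 32.3 mL/min/kg. Compound 2 therefore holds the higher of the two numbers, and the gap lies beyond the usual scatter of repeat measurements. Compound 3 `CC(C)(C)N1CCC(c2cc3c(ccc(=O)n3-c3c(Cl)cccc3Cl)c(-c3ccccc3Cl)n2)CC1` keeps all of compound 2 except one group: 2-chlorophenyl in place of 2,4-difluorophenyl on an aromatic carbon, next to the ring nitrogen (2-chlorophenyl in place of 2,4-difluorophenyl on an aromatic carbon). Both the group that leaves and the group that enters are built on one six-membered aromatic ring of carbon only. Among the measured compounds shown here, no measured pair shows what this swap does, since compound 1 and compound 2 carry the same 2,4-difluorophenyl group, so the data give no direct guide. The safest expectation in this assay is no change beyond the scatter, with no firm direction, and the estimate is a 1.1-fold lower number from compound 2 to compound 3 (0.03 log units; within the scatter). Compound 3 is expected to give about 30 mL/min/kg, with an estimated range from 15 mL/min/kg to 55 mL/min/kg.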

Compound 3, clearance: 25 mL/min/kg
Compound 3: the middle estimate sits 1.2-fold (0.08 log units) above what was measured; the range from low to high includes it.
By their numbers in this assay, from the lowest: compound 1; then compounds 3 and 2 (each within the scatter of the next).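

In this assay, among the compounds shown here, the swap of 2,4-difluorophenyl for 2-chlorophenyl on this aromatic carbon, next to the ring nitrogen, gives a 1.3-fold lower number from compound 2 to compound 3 (0.11 log units; within the scatter) and is the first direct reading of a change at this position. On this read-out, compound 2 and compound 3 cannot be told apart, so for this one pair, exchanging one substituted phenyl ring for another leaves clearance in rat within the normal spread of repeat measurements. No separate measurement helps to explain this result.

For the compounds shown here, the pair covers only two groups, both built on a six-membered aromatic ring of carbon only, so it cannot show whether clearance would stay within the scatter with a pyridine ring, a morpholine or a short alkyl chain on this carbon. It also leaves open whether the same exchange would give a similar result on the core of compound 1, where the ring nitrogen of compound 2 is absent.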